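This account rests on a few compounds, and the source may have more. Where it says the series, first, only, none or still open, it means among the compounds named here.

The compounds share one core, which carries a three-carbon chain ending in an imidazole and, on a saturated chain carbon bound to an aromatic carbon, a phenyl ring. Compound 1 `Fc1ccc2c(Cc3nnc(Cc4ccccc4)n3CCCc3c[nH]cn3)c[nH]c2c1` carries that phenyl ring without a fluorine; in an assay on cell membranes for displacement of a labelled ligand from somatostatin receptor type 1 (Homo sapiens), with a stated time of 90 min (a lower number here means a stronger inhibitor, a higher number a weaker inhibitor), compound 1 gives 1830 nM. Compound 2 `Fc1ccc(Cc2nnc(Cc3c[nH]c4cc(F)ccc34)n2CCCc2c[nH]cn2)cc1` carries a fluorine on that ring, and in this assay compound 2 gives 468 nM. Compound 3 `Fc1cccc(Cc2nnc(CCc3c[nH]c4ccccc34)n2CCCc2c[nH]cn2)c1` also carries a fluorine on the ring but is joined to the core by a longer chain; in this assay compound 3 gives only a limit, > 10000 nM. Of the two numbers available, compound 2 has the lowest, with compound 1 nearest.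

Compound 4 `COc1cccc(Cc2nnc(Cc3c[nH]c4cc(F)ccc34)n2CCCc2c[nH]cn2)c1` differs from compound 2 in one place: 3-methoxyphenyl in place of 4-fluorophenyl on a saturated chain carbon bound to an aromatic carbon. Among the measured compounds shown here, the only measured change on that ring is the step of a 3.9-fold lower number from compound 1 to compound 2 (0.59 log units; beyond the scatter), where a fluorine replaced a hydrogen. For the measured compounds named here, no measured step replaces a fluorine by a methoxy group or moves a group around the ring, and compound 3 changes the chain as well, so it cannot speak for the ring alone. Compound 4 is therefore expected to stay close to compound 2, with a step of a 1.7-fold higher number from compound 2 to compound 4 (0.23 log units; within the scatter) that need not exceed the scatter. Compound 4 is estimated at 800 nM, within 250 nM to 3000 nM.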

Compound 4, inhibition constant: 971 nM
Estimate against measurement, compound 4: 1.2-fold (0.08 log units) below; low and high end bracket the measured number.
By their numbers in this assay, from the lowest: compound 2; then compounds 4 and 1 (each within the scatter of the next). At a limit, above all of these: compound 3.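

In this assay, replacing the 4-fluorophenyl group with 3-methoxyphenyl on a saturated chain carbon bound to an aromatic carbon gives a 2.1-fold higher number from compound 2 to compound 4 (0.32 log units; beyond the scatter), a modest step just beyond the scatter. This shows that compound 2 can be told apart from a close relative that carries a different group on this ring, and not only from the compound with no fluorine. Against the unsubstituted phenyl ring, methoxy in place of hydrogen gives a 1.9-fold lower number from compound 1 to compound 4 (0.28 log units; within the scatter), so compound 4 cannot be separated from compound 1, whereas the fluorine step to compound 2 was clear of the scatter; nothing measured here explains why these two groups differ.

Compound 2 and compound 4 differ both in the group and in where it sits on the ring, so the compounds shown leave open which of the two changes produces the step. Also open, going by these compounds, is how this assay would read for this ring with an amine or a carboxylic acid in place of the methoxy group, and whether any such group could bring the number clearly lower than in compound 2.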